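Replacing the hydroxycyclobutyl of compound 3 by a tetramethyloxanyl

The source may hold more compounds than are shown below. What is called first, only, known or untested is meant among the compounds shown, and "the series" means these compounds.

Three analogues sharing one core have been measured in an assay on isolated protein for inhibition of histone acetyltransferase p300 (Homo sapiens), read by AlphaLISA, with a stated time of 20 min; a higher number here means a weaker inhibitor, a lower number a stronger inhibitor. Compound 1 `COc1ccc(CCc2nc3cc(-c4c(C)noc4C)ccc3n2[C@H]2CC[C@H](OC)CC2)cc1Cl` gives 97 nM, compound 2 `COc1ccc(CCc2nc3cc(-c4c(C)noc4C)ccc3n2[C@H]2CC[C@H](O)CC2)cc1Cl` gives 48 nM, and compound 3 `COc1ccc(CCc2nc3cc(-c4c(C)noc4C)ccc3n2[C@H]2C[C@H](O)C2)cc1Cl` gives 155 nM. Compound 3 therefore carries the highest of the three numbers, but its gap to compound 1 is within the scatter, while the step of a 3.2-fold higher number from compound 2 to compound 3 (0.51 log units; beyond the scatter) lies beyond it.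

Compound 4 `COc1ccc(CCc2nc3cc(-c4c(C)noc4C)ccc3n2C2CC(C)(C)OC(C)(C)C2)cc1Cl` differs from compound 3 by 2,2,6,6-tetramethyloxan-4-yl in place of 3-hydroxycyclobutyl on an aromatic nitrogen. For the measured compounds named here, two measured steps bear on this change. The step of a 3.2-fold higher number from compound 2 to compound 3 (0.51 log units; beyond the scatter) shows what the move from a six-membered to a four-membered ring cost, and the step of a 2.0-fold lower number from compound 1 to compound 2 (0.31 log units; beyond the scatter) shows the modest gain from a hydrogen-bond donor in place of a methyl ether on the ring. Compound 4 reverses the ring-size change but also loses the donor, so the two effects largely offset and the expected step of a 1.4-fold lower number from compound 3 to compound 4 (0.15 log units; within the scatter) is small. Compound 4 is thus estimated at 110 nM in this assay, with a range from 40 nM to 350 nM.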

Compound 4, half-maximal inhibitory concentration: 112 nM
For compound 4 the middle estimate is 1.0-fold (0.01 log units) below the measured one; the measured number falls inside the stated range.
By their numbers in this assay, from the lowest: compound 2; then compounds 1, 4 and 3 (each within the scatter of the next).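

On an aromatic nitrogen, the larger 2,2,6,6-tetramethyloxan-4-yl, with no hydrogen-bond donor, is tolerated in this assay about as well as the 3-hydroxycyclobutyl, with a 1.4-fold lower number from compound 3 to compound 4 (0.14 log units; within the scatter). It also stands level with the 4-methoxycyclohexyl, with a 1.2-fold higher number from compound 1 to compound 4 (0.06 log units; within the scatter), and only the 4-hydroxycyclohexyl separates from it, with a 2.3-fold higher number from compound 2 to compound 4 (0.37 log units; beyond the scatter). No measurement at hand explains these numbers.

Compound 4 changes the ring size, the ring oxygen and the four methyl groups in one step, so their separate contributions remain unresolved. A plain oxan-4-yl or a piperidin-4-yl amine on the same nitrogen would be needed to tell whether the methyl groups or the ring oxygen matter here.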